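Positional swap of the chlorophenyl group on the shared core

This account rests on a few compounds, and the source may have more. Where it says the series, first, only, none or still open, it means among the compounds named here.

Compound 1 `Oc1cccc(-c2cc(-c3cccnc3)nc(-c3cccc(Cl)c3)c2)c1` and compound 2 `Oc1cccc(-c2cc(-c3cccc(Cl)c3)nc(-c3ccccn3)c2)c1` carry the same hydroxyphenyl-bearing core as the rest of the set; in a functional assay on T47D cells (Homo sapiens) for cytotoxicity, read by CCK-8 assay and cell counting, with a stated time of 2 days (on this read-out higher numbers stand for weaker inhibition and lower numbers for stronger inhibition), compound 1 gives "not determined" (no result reported) and compound 2 gives "not determined" (no result reported), so neither adds a number to the series. Among the compounds with values here, compound 3 `Oc1cccc(-c2cc(-c3cccs3)nc(-c3ccccc3Cl)c2)c1` is the only member with a result: in this assay compound 3 gives 3990 nM, and with no second number in the set it stands alone, neither strong nor weak by comparison. Compound 4 `Oc1cccc(-c2cc(-c3cccc(Cl)c3)nc(-c3cccs3)c2)c1` differs from compound 3 in one place: 3-chlorophenyl in place of 2-chlorophenyl on an aromatic carbon. Within the data shown here, no measured pair shows what such a swap does here, so a step from compound 3 to compound 4 of a 1.1-fold lower number from compound 3 to compound 4 (0.06 log units; within the scatter) is expected, small and within the usual scatter in either direction. Compound 4 is estimated at 3500 nM, most likely between 1200 nM and 10000 nM.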

Compound 4, half-maximal inhibitory concentration: 3410 nM
For compound 4 the middle estimate is 1.0-fold (0.01 log units) above the measured one; low and high end bracket the measured number.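

In this assay, within the data shown here, the first measured pair on this position shows that 3-chlorophenyl in place of 2-chlorophenyl, with the thiophen-2-yl group kept, gives a step within the scatter (a 1.2-fold lower number from compound 3 to compound 4 (0.07 log units; within the scatter)). On this read-out, then, the two chlorophenyl isomers are not told apart at this position on the shared core. Nothing measured bears on why.

Going by these compounds, whether 4-chlorophenyl, or a phenyl carrying an amine or a carboxylic acid, would separate from this pair stays open. On these data alone, the contribution of the thiophen-2-yl group also remains open.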